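The compounds below may be only part of what the source reports. "The series", "measured", "known", "first", "only" and "open" are said of these compounds alone.

Measured so far in an assay on membranes from CHO cells for displacement of a labelled ligand from adenosine receptor A1 (Homo sapiens), read by scintillation counting, with a stated time of 60 min, tested at 1 uM; on this read-out higher numbers stand for more inhibition at the one concentration tested (going by the name of the read-out) and lower numbers for less inhibition:
- compound 1 `CCCC(=O)C1=C(C)NC(=O)NC1c1ccco1`: 1%
- compound 2 `CC1=C(C(=O)CC(C)C)C(c2ccco2)NC(=O)N1`: 16%

Compound 2 stands highest of the two numbers in this assay; its nearest neighbour is compound 1, and the step between them reads a number 15 percentage points higher from compound 1 to compound 2 (beyond the scatter), which is beyond the scatter.

Compound 3 `CCNC(=O)C1=C(C)NC(=O)NC1c1ccco1` has not yet been measured in this assay. It differs from compound 2 in one place: ethylamino in place of isobutyl on a carbonyl carbon.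

For the measured compounds named here, the one measured step, a number 15 percentage points higher from compound 1 to compound 2 (beyond the scatter), changes the chain on the carbonyl carbon and so touches the same position, but it keeps the chain saturated carbon throughout, whereas the step to compound 3 replaces the whole chain by a group with one hydrogen-bond donor. Going by the values given here, no measured step of that kind is available, so the direction can only be guessed from the fact that the gain in compound 2 was tied to the branched chain, which compound 3 no longer carries.

For compound 3 the number is therefore expected to move back towards that of compound 1, by a step of about a number 8 percentage points lower from compound 2 to compound 3 (within the scatter), which is within the scatter. The estimate for compound 3 is 8%, with a range from 0% to 25%.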

Compound 3, a percentage reported as inhibition, at one concentration (the size of the read-out at that concentration, not a potency): 2%
Beside the measured number, compound 3's estimate is 6 percentage points above it; measured number inside the range.
By their numbers in this assay, from the lowest: compounds 1 and 3 (each within the scatter of the next); then compound 2.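

In this assay, the change from isobutylcarbonyl to ethylcarbamoyl gives a number 14 percentage points lower from compound 2 to compound 3 (beyond the scatter), so the number at this position has now been seen to go down as well as up, with a change that brings in nitrogen and a hydrogen-bond donor on the carbonyl carbon. Ethylamino in place of propyl on the same carbonyl carbon gives a number 1 percentage points higher from compound 1 to compound 3 (within the scatter), so in this assay the two groups cannot be told apart, and swapping a saturated carbon chain for ethylamino need not by itself change the number. Of the three compounds, only compound 2, with isobutyl, stands apart from both others, and nothing available here bears on the reason for that difference.

From the compounds shown here alone, it remains open whether the higher number of compound 2 goes with the branching of isobutyl or with chain length alone, which a straight butyl chain on the carbonyl carbon would help to separate. Also open, going by these compounds, is whether a nitrogen-linked group can match compound 2 when it carries the same branching, as isobutylamino would on this carbonyl carbon.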